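Chalcone series: swapping the aryl group on the alkene

The source may report more compounds than this note shows. Statements on the series, on what has been measured and on what is new or still open speak of the compounds shown alone.

Two members of the series have been measured in a functional assay on MCF7 cells (Homo sapiens) for cytotoxicity, read by sulforhodamine B assay, with a stated time of 48 h; on this read-out higher numbers stand for weaker inhibition and lower numbers for stronger inhibition. Compound 1, `COc1cc(/C=C/C(=O)c2ccc(N)c(-c3ccc(F)cc3)c2)ccc1O`, gives 10500 nM in this assay. Compound 2, `O=C(/C=C/c1ccc(Br)cc1)c1cccc(-c2cccc(F)c2)c1`, gives 18300 nM in this assay. Of the two numbers in hand, compound 2 is the one from which the next step is taken; compound 1 lies within the usual scatter of it, so the two cannot be placed in order against one another.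

Compound 3, `COc1ccccc1/C=C/C(=O)c1cccc(-c2cccc(F)c2)c1`, has not yet been measured. It differs from compound 2 in a single place: 2-methoxyphenyl in place of 4-bromophenyl on a double-bonded chain carbon bound to a double-bonded chain carbon. Going by the values given here, no pair of measured compounds shows the effect of this exchange, so the size of the step in this assay rests on judgement alone. The expectation is a small step, either without direction beyond the scatter or toward a somewhat larger number, as the shared core and its linking chain remain as in compound 2. On that basis compound 3 is expected to give about 22000 nM in this assay, with a range of 7000 nM to 65000 nM. The estimated step of a 1.2-fold higher number from compound 2 to compound 3 (0.08 log units; within the scatter) is therefore expected to be modest.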

Compound 3, half-maximal inhibitory concentration: 18900 nM
For compound 3 the middle estimate is 1.2-fold (0.07 log units) above the measured one; low and high end bracket the measured number.
By their numbers in this assay, from the lowest: compounds 1, 2 and 3 (each within the scatter of the next).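

Notes on the aryl group at this place: in this assay the exchange of 4-bromophenyl for 2-methoxyphenyl on a double-bonded chain carbon bound to a double-bonded chain carbon gives a 1.0-fold higher number from compound 2 to compound 3 (0.01 log units; within the scatter) and is the first single-place step read in the series, so the two groups cannot be told apart on this core. The exchange is not a close one on paper: 7 heavy atoms with bromine leave, 8 heavy atoms with oxygen enter, and a hydrogen-bond acceptor appears where the leaving group has none, yet none of these differences comes with a step beyond the scatter in this pair. Nothing available bears on why the two groups read alike.

Still open, from the compounds shown here alone, is whether any group at this place moves the number beyond the scatter: a carboxylic acid, a dimethylamino group or a 4-methoxyphenyl group would each test this on the same core. Also open, going by these compounds, is whether the exchange reads the same way on the core of compound 1, which carries an amine.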